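Benzyl in place of phenyl on the amide nitrogen

The source may hold more compounds than are shown below. What is called first, only, known or untested is meant among the compounds shown, and "the series" means these compounds.

Compounds measured in a functional assay on HCT-116 cells (Homo sapiens) for cytotoxicity; a lower number here means a stronger inhibitor, a higher number a weaker inhibitor:
compound 1, `CN1CCN(c2ccc(C(=O)Nc3n[nH]c4cc(C(=O)NC(C)(C)c5ccccc5)sc34)cc2)CC1`, 35 nM
compound 2, `CCNC(=O)c1cc2[nH]nc(NC(=O)c3ccc(N4CCN(C)CC4)cc3)c2s1`, 710 nM
compound 3, `CN1CCN(c2ccc(C(=O)Nc3n[nH]c4cc(C(=O)Nc5ccccc5)sc34)cc2)CC1`, "not active" (no number reported)

Compound 3 gives no number in this assay and is reported as "not active" (no number reported), so it stands outside the range of the other two. Compound 4, `CN1CCN(c2ccc(C(=O)Nc3n[nH]c4cc(C(=O)NCc5ccccc5)sc34)cc2)CC1`, differs from compound 3 by benzyl in place of phenyl on an amide-type nitrogen. For the measured compounds named here, no measured step has compound 3 at one end. Going by the values given here, the only step of this kind, a 20-fold higher number from compound 1 to compound 2 (1.31 log units; beyond the scatter), shows that what sits on this amide nitrogen shifts the number strongly. Benzyl places compound 4 between the inactive phenyl of compound 3 and the potent 1-methyl-1-phenylethyl of compound 1, so a number is expected, but a weak one. Compound 4 is expected at 400 nM, within 60 nM to 4000 nM.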

Compound 4, half-maximal inhibitory concentration: 310 nM
Compound 4: the middle estimate sits 1.3-fold (0.11 log units) above what was measured, within the range that was stated.
By their numbers in this assay, from the lowest: compound 1; then compound 4; then compound 2.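

In this assay the benzyl of compound 4 gives a number where the phenyl of compound 3 gave none, so this change alone separates "not active" from a measurable value. Benzyl still falls short of 1-methyl-1-phenylethyl, with an 8.9-fold higher number from compound 1 to compound 4 (0.95 log units; beyond the scatter) on that change, while phenyl in place of methyl on the saturated chain carbon gives a 2.3-fold lower number from compound 2 to compound 4 (0.36 log units; beyond the scatter) and so recovers only part of the loss seen with ethyl. Nothing available explains these shifts. The compounds shown leave open how a cyclohexylmethyl or pyridylmethyl group on this amide nitrogen would compare with benzyl, and whether a longer chain such as 2-phenylethyl would lower the number further.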